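The compounds below may be only part of what the source reports. "The series", "measured", "known", "first", "only" and "open" are said of these compounds alone.

In a functional assay on Jurkat cells (Homo sapiens) for inhibition, read by CCK-8 assay, with a stated time of 48 h (a higher number here means a weaker inhibitor of growth, a lower number a stronger inhibitor of growth), compound 1 `COc1ccc(CNc2nc(Nc3ccc(N4CCN(C)CC4)cn3)ncc2Cl)cc1` gives 12900 nM and compound 3 `COc1ccc(Nc2nc(Nc3ccc(N4CCN(C)CC4)cn3)ncc2Cl)cc1` gives 11200 nM, two values within the scatter of each other. Compound 2 `CN1CCN(c2ccc(Nc3ncc(Cl)c(NCc4ccco4)n3)nc2)CC1` reads > 100000 nM, which is a limit of the assay and not a number. Compound 3 therefore stands level with compound 1, and the change seen in an at least 8.9-fold lower number from compound 2 to compound 3 (0.95 log units; beyond the scatter) lies beyond the scatter.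

Compound 4 `COc1cccc(Nc2nc(Nc3ccc(N4CCN(C)CC4)cn3)ncc2Cl)c1` has the same atoms as compound 3, joined differently: 3-methoxyphenyl in place of 4-methoxyphenyl on a nitrogen on an aromatic ring. It carries 3-methoxyphenyl in place of 4-methoxyphenyl on a nitrogen on an aromatic ring. For the measured compounds named here, no measured step moves the methoxy group itself, so the guides are indirect. Replacing 4-methoxybenzyl with 4-methoxyphenyl gave a 1.2-fold lower number from compound 1 to compound 3 (0.06 log units; within the scatter), within the scatter. Replacing 4-methoxyphenyl with furan-2-yl gave an at least 7.7-fold higher number from compound 1 to compound 2 (0.88 log units; beyond the scatter), beyond it. Compound 4 keeps a methoxy-bearing six-membered aromatic ring, so the milder of these steps seems the closer guide. The expected step, a 1.1-fold higher number from compound 3 to compound 4 (0.03 log units; within the scatter), stays within the scatter. Compound 4 is expected at about 12000 nM, with an estimated range from 5000 nM to 30000 nM.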

Compound 4, concentration for 50% growth inhibition: 15800 nM
Estimate against measurement, compound 4: 1.3-fold (0.12 log units) below; the range from low to high includes it.
By their numbers in this assay, from the lowest: compounds 3, 1 and 4 (each within the scatter of the next). At a limit, above all of these: compound 2.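

In this assay, for the compounds shown here, moving the methoxy group for the first time, with 3-methoxyphenyl in place of 4-methoxyphenyl on a nitrogen on an aromatic ring, gives a 1.4-fold higher number from compound 3 to compound 4 (0.15 log units; within the scatter), so these two placings cannot be told apart here. With 3-methoxyphenyl in place of 4-methoxybenzyl the result is a 1.2-fold higher number from compound 1 to compound 4 (0.09 log units; within the scatter), so compounds 1, 3 and 4 read alike, whereas 3-methoxyphenyl in place of (furan-2-yl)methyl gives an at least 6.3-fold lower number from compound 2 to compound 4 (0.80 log units; beyond the scatter). The reading of compound 2 is a limit and not a number, so that last step has no fixed size: the limit of > 100000 nM in this assay, at which 1 of the 4 values shown sits.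

A plain phenyl, or a hydroxyl or a chlorine in place of the methoxy group, would show whether the methoxy group matters at all. Going by these compounds, whether any group at this place can bring the number well below those of compounds 1, 3 and 4 also stays open.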